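The compounds below may be only part of what the source reports. "The series", "measured", "known", "first", "only" and "open" are said of these compounds alone.

Of the compounds shown here, two have been measured in an ADME assay on microsomes from liver (Homo sapiens) for metabolic stability; a lower number here means slower removal, a higher number faster removal of the compound. Compound 1 `CC(=O)N1CC(Oc2cc(-c3cnnc4c3ncn4C(C)C)ccc2F)C1` reads < 8 mL.min-1.g-1, which is a limit of the assay and not a number. For the measured compounds named here, compound 2 `CCn1cnc2c(-c3ccc(F)c(-c4ccc(C#N)cc4OC)c3)cnnc21` gives 32 mL.min-1.g-1, the only actual number so far in this assay. Compound 3 `CCn1cnc2c(-c3ccc(F)c(-c4ccc(S(=O)(=O)C(C)C)cc4OC)c3)cnnc21` differs from compound 2 in one place: isopropylsulfonyl stands in place of cyano on an aromatic carbon, meta to a methoxy group (isopropylsulfonyl in place of cyano on an aromatic carbon). Going by the values given here, no measured step between compounds differing in one place is available, so the expectation starts from compound 2 at 32 mL.min-1.g-1 and rests on the structural change alone. No shift beyond the usual scatter is foreseen, and a slight rise is thought no less likely than a slight fall. The expected step is no change at the digits printed from compound 2 to compound 3 (within the scatter). Compound 3 is expected at 32 mL.min-1.g-1, with an estimated range from 14 mL.min-1.g-1 to 70 mL.min-1.g-1.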

Compound 3, intrinsic clearance in microsomes: 84 mL.min-1.g-1
The estimate for compound 3 lay 2.6-fold (0.42 log units) below the measured number; measured number above the stated range.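

Isopropylsulfonyl in place of cyano brought a 2.6-fold higher number from compound 2 to compound 3 (0.42 log units; beyond the scatter) in this assay, and this is the first measured step at this place, an aromatic carbon meta to a methoxy group and para to a large group. It shows that the read-out responds to what stands at this place, and that here the exchange goes with faster removal, though this rests on a single pair. Nothing measured among these compounds accounts for the size or direction of this step.

On these data alone, whether the sulfonyl or the isopropyl part carries the step stays open, and a methylsulfonyl group or a primary amine at this place would speak to that. As far as these compounds go, it is equally open whether the same exchange would give a similar step on the core of compound 1.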